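From cyclopropyl back to a methoxyphenyl group

This account rests on a few compounds, and the source may have more. Where it says the series, first, only, none or still open, it means among the compounds named here.

Compound 1 `COc1ccccc1NC1=CC(=O)c2c(nc3n2[C@H]2OC[C@@H](O)[C@H]2OC3)C1=O`: 7460 nM
Compound 2 `O=C1C(NC2CC2)=CC(=O)c2c1nc1n2[C@H]2OC[C@@H](O)[C@H]2OC1`: > 16000 nM

In a functional assay on HeLa cells (Homo sapiens) for inhibition, read by sulforhodamine B assay (a lower number here means a stronger inhibitor, a higher number a weaker inhibitor), compound 1 gives a true number, 7460 nM.

Compound 2 gives > 16000 nM, which is a limit and not a number.

Compound 3 `COc1cccc(NC2=CC(=O)c3c(nc4n3[C@H]3OC[C@@H](O)[C@H]3OC4)C2=O)c1` has not yet been measured. The change from compound 2 is 3-methoxyphenyl in place of cyclopropyl on an amine nitrogen. Among the compounds with values here, one measured step bears on this, an at least 2.1-fold higher number from compound 1 to compound 2 (0.33 log units; beyond the scatter). Compound 3 has the 3-methoxyphenyl group rather than the 2-methoxyphenyl group of compound 1, so that step, read backwards, is only a rough guide. It leads to the expectation of a lower number in this assay, with compound 3 landing near compound 1. The expected change is an at least 2.2-fold lower number from compound 2 to compound 3 (0.35 log units; beyond the scatter). For compound 3 the estimate is 7000 nM, with an expected range of 2500 nM to 18000 nM.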

Compound 3, half-maximal inhibitory concentration: > 8000 nM
Compound 3 gave a limit, no number; the forecaster's own chance of this, stated with the estimate: 25%; middle value at least 1.1-fold (0.05 log units) away from the limit.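

Replacing the 2-methoxyphenyl group on the amine nitrogen with the 3-methoxyphenyl group gives, in this assay, an at least 1.0-fold higher number from compound 1 to compound 3 (0.03 log units; that floor lies within the scatter). The value of compound 3 is a limit and not a number, so this step fixes only a floor: the true number could match that of compound 1 or lie well beyond it, and the effect of moving the methoxy group remains unsettled. The step from cyclopropyl to 3-methoxyphenyl cannot be read, as compound 2 and compound 3 both give only limits.

Among these compounds, only compound 1 gives a true number, 7460 nM, so there is no measured pair from which to judge a change in this assay beyond that value. From the compounds shown here alone, how a plain phenyl group, a benzyl group or a longer chain on the same amine nitrogen would compare remains open.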